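A chloro for a fluoro at the assay limit

A few compounds are considered here, and "the series" means these few. Any claim that something is new, unique, unknown or untested is made for them only; others in the source may bear on it.

Measured so far in a functional assay on A549 cells (Homo sapiens) for antiproliferative activity, read by spectrophotometry, with a stated time of 2 days; a lower number here means a stronger inhibitor of growth, a higher number a weaker inhibitor of growth:
- Compound 1 `COc1ccc(Nc2ncc(C(F)(F)F)c(N3Cc4cccc(N(C)S(C)(=O)=O)c4C3)n2)cc1C(F)(F)F` gives > 30000 nM as a limit
- Compound 2 `Cc1cc(F)ccc1Nc1ncc(C(F)(F)F)c(N2Cc3cccc(N(C)S(C)(=O)=O)c3C2)n1` gives > 30000 nM as a limit

Compound 2 gives > 30000 nM as a limit and not as a number. All the data so far come down to the limit of > 30000 nM in this assay, at which 2 of the 2 values shown sit, and nothing more.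

Compound 3 `Cc1cc(Cl)ccc1Nc1ncc(C(F)(F)F)c(N2Cc3cccc(N(C)S(C)(=O)=O)c3C2)n1` alters compound 2 in one place: chloro in place of fluoro on an aromatic carbon, with chloro in place of fluoro on an aromatic carbon, para to a large group. Among the compounds with values here, the one measured step is a step that the two limits leave unreadable from compound 1 to compound 2 and so offers no size to carry over. With no readable step to go on, none beyond the scatter is expected in this assay and compound 3 will probably also report only a limit. The expected change is a number no higher from compound 2 to compound 3 (the limit leaves the size open) as an estimate. For compound 3 the estimated value is 30000 nM with an expected range from 15000 nM to 60000 nM in this estimate.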

Compound 3, concentration for 50% growth inhibition: 25500 nM
Estimate against measurement, compound 3: 1.2-fold (0.07 log units) above; the range from low to high includes it.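

In this assay, within the data shown here, compound 3 gives 25500 nM, a number rather than a limit, so a chloro on this carbon, para to a large group, yields the first readable value. Chloro in place of fluoro gives an at least 1.1-fold lower number from compound 2 to compound 3 (0.07 log units; that floor lies within the scatter), and the 4-chloro-2-methylphenyl group in place of 4-methoxy-3-(trifluoromethyl)phenyl gives an at least 1.1-fold lower number from compound 1 to compound 3 (0.07 log units; that floor lies within the scatter). The true size of either step remains unknown because each starts from a limit: the limit of > 30000 nM in this assay, at which 2 of the 3 values shown sit.

The compounds shown leave open whether bromo or a nitrile on the same carbon would give a number clearly lower than that of compound 3. No compound shown carries the chloro without the methyl group on the same ring. Whether the number would differ without that methyl group is also left open.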